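Aryl Change on the Sulfur-Linked Chain, Compound 1 to Compound 4

The source may report more compounds than this note shows. Statements on the series, on what has been measured and on what is new or still open speak of the compounds shown alone.

Three analogues share one core and differ in the aryl group carried on the sulfur-linked chain. In an assay on isolated protein for inhibition of Amine oxidase [flavin-containing] B (Homo sapiens) (a lower number here means a stronger inhibitor, a higher number a weaker inhibitor), compound 1 `C#CCNC1CCc2c(SCCc3cccc(Br)c3)cccc21` gives 30500 nM, the highest of the three numbers. Compound 2 `C#CCNC1CCc2c(SCCc3ccc(C(F)(F)F)cc3)cccc21` gives 16100 nM, within the scatter of compound 1. Compound 3 `C#CCNC1CCc2c(SCc3ccc(C(F)(F)F)cc3)cccc21` gives 9680 nM, and the gap from compound 1 to compound 3 lies beyond the scatter. Compound 4 `C#CCNC1CCc2c(SCCc3ccc(Cl)c(Cl)c3)cccc21` is not yet measured; it differs from compound 1 as 3,4-dichlorophenyl in place of 3-bromophenyl on a saturated chain carbon, two bonds along the chain from a sulfur. Among the compounds with values here, no measured pair isolates this change. A modest step to a lower number from compound 1 to compound 4 is expected, possibly beyond the scatter, since compound 2 gives 16100 nM with a differently substituted ring on the same chain. The estimate for compound 4 in this assay is 13000 nM, ranging from 4500 nM to 40000 nM, an expected step of a 2.3-fold lower number from compound 1 to compound 4 (0.37 log units; beyond the scatter).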

Compound 4, half-maximal inhibitory concentration: 3850 nM
Estimate against measurement, compound 4: 3.4-fold (0.53 log units) above, outside the stated range (below it).
By their numbers in this assay, from the lowest: compound 4; then compounds 3, 2 and 1 (each within the scatter of the next, the first and the last beyond it).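

In this assay, the aryl group on a saturated chain carbon, two bonds along the chain from a sulfur, is now shown by a single-place change to affect the number: 3,4-dichlorophenyl in place of 3-bromophenyl gives a 7.9-fold lower number from compound 1 to compound 4 (0.90 log units; beyond the scatter). Within the data shown here, this is the first pair to isolate one change, and its step lies beyond the scatter. Nothing available explains the size of this step.

Still open, as far as these compounds go, is whether both chlorines are needed, which a monochlorophenyl group on the same chain would test. Equally open, from the compounds shown here alone, is how unsubstituted phenyl or 3,4-difluorophenyl would compare.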